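Adding a phenyl to an amide-type nitrogen at the limit

The source may hold more compounds than are shown below. What is called first, only, known or untested is meant among the compounds shown, and "the series" means these compounds.

In a functional assay on A-375 cells (Homo sapiens) for antiproliferative activity, read by MTT assay, with a stated time of 72 h (on this read-out higher numbers stand for weaker inhibition and lower numbers for stronger inhibition), compound 2 (`O=C1COc2ccc(-c3cnc4ccccc4c3)cc2N1`) gives > 40000 nM as a limit of the assay, not a number. Compound 1 (`O=C1COc2ccc(-c3cnc4ccccc4c3)cc2N1c1ccc(F)cc1`), with 4-fluorophenyl on that amide-type nitrogen, gives > 40000 nM as a limit too. Among the measured compounds shown here, that leaves a step that the two limits leave unreadable from compound 1 to compound 2 as the only measured step, and it has no readable size. Compound 3 (`O=C1COc2ccc(-c3cnc4ccccc4c3)cc2N1c1ccccc1`) carries phenyl in place of hydrogen on an amide-type nitrogen in a ring as its change, phenyl in place of hydrogen on that nitrogen. For the measured compounds named here, with the limit of > 40000 nM in this assay, at which 2 of the 2 values shown sit, as the only guide, no step beyond the scatter is expected in this assay and another limit is likely. The expected move is a number no higher from compound 2 to compound 3 (the limit leaves the size open) in size. Compound 3 is estimated at 40000 nM with an expected range from 15000 nM to 80000 nM for its value.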

Compound 3, half-maximal inhibitory concentration: > 40000 nM
Compound 3: a limit, no number; the forecaster's own chance of this, stated with the estimate: 85%; the middle value sits exactly at the limit.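

Among the compounds shown here, compound 1, compound 2 and compound 3 all stand at a limit of the assay rather than at a number, so no step among them can be read. The compounds shown leave open whether the group on the amide-type nitrogen affects inhibition at all.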